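Bromo on the phenyl: expectation for compound 4

The source may hold more compounds than are shown below. What is called first, only, known or untested is meant among the compounds shown, and "the series" means these compounds.

Compound 1 `Cc1cc(O)c(C(=O)/C=C/c2ccc(F)cc2)c(-c2ccccc2)c1C(=O)/C=C/c1ccc(F)cc1` is the reference for this step. In a functional assay on MDA-MB-231 cells (Homo sapiens) for cytotoxicity, read by MTT assay, with a stated time of 24 h (a lower number here means a stronger inhibitor, a higher number a weaker inhibitor), compound 1 gives 20000 nM. For the measured compounds named here, compound 3 `Cc1cc(O)c(C(=O)/C=C/c2ccc3ccccc3c2)c(-c2ccccc2)c1C(=O)/C=C/c1ccc2ccccc2c1` gives 30000 nM in this assay; that number and the one for compound 1 lie within the scatter of each other, so no ranking between them is claimed. Compound 2 `COc1ccc(/C=C/C(=O)c2c(C)cc(O)c(C(=O)/C=C/c3ccc(OC)cc3)c2-c2ccccc2)cc1` gives "not active" (no number reported) in this assay, with no number to set against the other two. Of the two numbers reported, that of compound 1 is the smaller, but the gap to compound 3 is within the scatter and carries no ranking.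

Compound 4 `Cc1cc(O)c(C(=O)/C=C/c2ccc(F)cc2)c(-c2ccc(Br)cc2)c1C(=O)/C=C/c1ccc(F)cc1` differs from compound 1 in one place: bromo in place of hydrogen on an aromatic carbon. Going by the values given here, no measured pair isolates such a change on the phenyl, so nothing here shows how this assay answers to it; the measured compounds differ from one another elsewhere, and those differences left the numbers within the scatter or removed them. Compound 4 is therefore expected to stay close to compound 1, with a step of a 1.3-fold lower number from compound 1 to compound 4 (0.10 log units; within the scatter) that is not expected to go beyond the scatter in either direction. For compound 4 the estimate in this assay is 16000 nM, within 6000 nM to 45000 nM.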

Compound 4, half-maximal inhibitory concentration: 22300 nM
Estimate against measurement, compound 4: 1.4-fold (0.14 log units) below, within the range that was stated.
By their numbers in this assay, from the lowest: compounds 1, 4 and 3 (each within the scatter of the next).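

For the compounds shown here, the pair gives the first reading at the phenyl, which the earlier compounds, differing from one another only elsewhere, could not give. In this assay the change of phenyl to 4-bromophenyl, on an aromatic carbon and para to a large group, gives a 1.1-fold higher number from compound 1 to compound 4 (0.05 log units; within the scatter) and so leaves the number within the scatter. At this position, one added heavy atom in the form of bromo therefore produces no readable change in this read-out, and no measured property bears on why this is so.

Going by these compounds, one substituent cannot show whether the position is indifferent to change in general, and it remains open whether an amine or a carboxylic acid in place of the same hydrogen would move the number beyond the scatter. On these data alone, it is also open whether any group at this position can take the series beyond the scatter on the stronger side of compound 1 in this assay.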